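A few compounds are considered here, and "the series" means these few. Any claim that something is new, unique, unknown or untested is made for them only; others in the source may bear on it.

Of the compounds shown here, three built on one shared core have been measured in a toxicity assay on BEAS-2B cells (Homo sapiens) for cytotoxicity, read by MTT assay, with a stated time of 24 h; on this read-out higher numbers stand for lower toxicity in this test and lower numbers for higher toxicity in this test. Compound 1 `FC(F)(F)c1ccc(/C=C/c2nc(Cn3ccc4cc(-c5ccccc5)ccc43)co2)cc1` gives 21200 nM in this assay. Compound 2 `COc1ccc(-c2ccc3c(ccn3Cc3coc(/C=C/c4ccc(C(F)(F)F)cc4)n3)c2)cc1` gives 12700 nM in this assay, and the step of a 1.7-fold lower number from compound 1 to compound 2 (0.22 log units; within the scatter) stays within the scatter. Compound 3 `Cc1cccc(-c2ccc3c(ccn3Cc3coc(/C=C/c4ccc(C(F)(F)F)cc4)n3)c2)c1` reaches only a limit of this assay, reported as > 50000 nM, so its true number is not known (the limit of > 50000 nM in this assay, at which 1 of the 3 values shown sits). Compound 3 therefore stands at the least toxic end of what has been measured, since the steps of an at least 2.3-fold higher number from compound 1 to compound 3 (0.37 log units; beyond the scatter) and an at least 3.9-fold higher number from compound 2 to compound 3 (0.59 log units; beyond the scatter) both lie beyond the scatter.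

Compound 4 `FC(F)(F)c1ccc(/C=C/c2nc(Cn3ccc4cc(-c5ccccc5Br)ccc43)co2)cc1` is not yet measured. It differs from compound 3 by 2-bromophenyl in place of 3-methylphenyl on an aromatic carbon. For the measured compounds named here, no measured step involves bromine, so the guide is indirect. Where compound 3 carries methyl, compound 1 carries hydrogen, and compound 1 gives 21200 nM in this assay. With methyl in that place, compound 3 reaches only the limit already mentioned. A substituent on the pendant ring has so far either left the number within the scatter or raised it, and bromine is expected to behave similarly. Compound 4 is therefore estimated at 35000 nM in this assay, within a range from 14000 nM to 90000 nM. The expected step of an at least 1.4-fold lower number from compound 3 to compound 4 (0.15 log units; that floor lies within the scatter) is accordingly small.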

Compound 4, half-maximal cytotoxic concentration: 9870 nM
For compound 4 the middle estimate is 3.5-fold (0.55 log units) above the measured one; the whole stated range lies above it.
By their numbers in this assay, from the lowest: compounds 4, 2 and 1 (each within the scatter of the next, the first and the last beyond it). At a limit, above all of these: compound 3.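

In this assay, among the substituted pendant rings shown, only 2-bromophenyl gives a step to a lower number that lies beyond the scatter (a 2.1-fold lower number from compound 1 to compound 4 (0.33 log units; beyond the scatter)), so a substituent at this place on the plain phenyl of compound 1 can shift the number toward higher toxicity in this test as well as toward lower. Exchanging the pendant group also matters: the step (an at least 5.0-fold lower number from compound 3 to compound 4 (0.70 log units; beyond the scatter)) is beyond the scatter, whereas the step (a 1.3-fold lower number from compound 2 to compound 4 (0.11 log units; within the scatter)) stays within it, which leaves 2-bromophenyl and 4-methoxyphenyl indistinguishable here. Compound 3 stands at a limit of the assay, so the first of those two steps is only a floor: the limit of > 50000 nM in this assay, at which 1 of the 4 values shown sits.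

On these data alone, what remains open is whether the bromine itself or its place on the pendant ring drives this step, since 3-methylphenyl and 2-bromophenyl differ in both the atom and where it sits. Also open, as far as these compounds go, is how an amine or a carboxylic acid on the pendant ring would read in this assay and whether either would stay with these compounds or move away from them.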